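The source may hold more compounds than are shown below. What is called first, only, known or untested is meant among the compounds shown, and "the series" means these compounds.

Compound 1 `COc1ccc(/C=C(/F)c2cc(OC)c(OC)c(OC)c2)cc1O`: 1700 nM
Compound 2 `COc1cc(/C=C\c2cc(O)c3ccsc3c2)cc(OC)c1OC`: 87 nM
Compound 3 `COc1ccc(/C(F)=C(\F)c2cc(OC)c(OC)c(OC)c2)cc1[N+](=O)[O-]`: 2300000 nM

These three compounds were tested in a functional assay on cells (Endothelial cell, Bos taurus) for antiproliferative activity; on this read-out lower numbers stand for stronger inhibition and higher numbers for weaker inhibition. Of the three numbers, compound 3 has by far the highest, which on this read-out means the weakest inhibition of cell growth. The gap to compound 1, the nearest of the other two, is far beyond the usual scatter of repeated measurements, and the gap to compound 2, the furthest, is wider still. Compound 3 is therefore the weakest inhibitor among the compounds measured.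

The next compound, compound 4 `COc1ccc(/C(F)=C(\F)c2cc(OC)c(OC)c(OC)c2)cc1N`, has not yet been measured. It differs from compound 3 in one place: amino in place of nitro on an aromatic carbon. Everything else in the two structures is the same.

Among the compounds with values here, no step between two measured compounds is available for this change, so the expectation rests on where compound 3 stands. Because compound 3 gives 2300000 nM, a value far above every other number in this assay, there is much room for improvement, and a large step downward, toward stronger inhibition, is expected in this assay as a 230-fold lower number from compound 3 to compound 4 (2.36 log units; beyond the scatter). Compound 4 is estimated at 10000 nM, with a plausible range from 500 nM to 500000 nM.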

Compound 4, half-maximal inhibitory concentration: 204000 nM
The estimate for compound 4 lay 20-fold (1.31 log units) below the measured number; measured number inside the range.
By their numbers in this assay, from the lowest: compound 2; then compound 1; then compound 4; then compound 3.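

Amino in place of nitro on an aromatic carbon, ortho to a methoxy group, gives an 11-fold lower number from compound 3 to compound 4 (1.05 log units; beyond the scatter) in this assay. Within the data shown here, this is the first direct comparison, and with the rest of the structure unchanged, it shows that the group at this one place has a large effect on the read-out. Even so, compound 4 gives 204000 nM, which remains a high number on this read-out, so the step is a real improvement but leaves inhibition weak. The data shown offer nothing that explains this step.

The compounds shown leave open how other groups at this place, such as a nitrile, a carboxylic acid or a dimethylamino group, would compare with amino and nitro, and so whether the trend follows any simple rule. Among these compounds, they also leave open whether the same exchange of nitro for amino would produce a step of similar size on a different core, since this single pair is the only evidence for it.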